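A few compounds are considered here, and "the series" means these few. Any claim that something is new, unique, unknown or untested is made for them only; others in the source may bear on it.

Working notes on the series in a functional assay on A549 cells (Homo sapiens) for inhibition, read by MTT assay, with a stated time of 24 h; on this read-out higher numbers stand for weaker inhibition and lower numbers for stronger inhibition: compound 1 `CC1(C)[C@H]2CC[C@]1(C)N(Cc1cn(-c3ccccc3Br)nn1)C(=O)C2` gives 130 nM, compound 2 `CC1(C)[C@H]2CC[C@]1(C)N(Cc1cn(-c3ccccc3Cl)nn1)C(=O)C2` gives 70 nM, and compound 3 `Cc1ccccc1-n1cc(CN2C(=O)C[C@@H]3CC[C@@]2(C)C3(C)C)nn1` gives 90 nM, so compound 3 stands level with the other two within the scatter. Compound 4 `COc1cccc(-n2cc(CN3C(=O)C[C@@H]4CC[C@@]3(C)C4(C)C)nn2)c1` carries 3-methoxyphenyl in place of 2-methylphenyl on an aromatic nitrogen. The nearest measured steps are a 1.9-fold lower number from compound 1 to compound 2 (0.27 log units; within the scatter), a 1.4-fold lower number from compound 1 to compound 3 (0.16 log units; within the scatter) and a 1.3-fold higher number from compound 2 to compound 3 (0.11 log units; within the scatter). For the measured compounds named here, all are within the scatter, but each swaps only one group on an aromatic carbon, and no methoxy compound has been measured. The expected change is a 1.1-fold higher number from compound 3 to compound 4 (0.05 log units; within the scatter), which stays within the scatter, with no firm direction. Estimated in this assay, compound 4 comes to 100 nM, with a range of 40 nM to 250 nM.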

Compound 4, half-maximal inhibitory concentration: 240 nM
For compound 4 the middle estimate is 2.4-fold (0.38 log units) below the measured one; the range from low to high includes it.
By their numbers in this assay, from the lowest: compounds 2, 3, 1 and 4 (each within the scatter of the next, the first and the last beyond it).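

For the compounds shown here, replacing the 2-substituted phenyl groups with 3-methoxyphenyl on the aromatic nitrogen gives the first steps beyond the scatter, both modest: a 2.7-fold higher number from compound 3 to compound 4 (0.43 log units; beyond the scatter) and a 3.4-fold higher number from compound 2 to compound 4 (0.54 log units; beyond the scatter), while a 1.8-fold higher number from compound 1 to compound 4 (0.27 log units; within the scatter) stays within it. This position therefore responds to a change of the whole aryl group, whereas bromo, chloro and methyl on the aromatic carbon stayed within the scatter of each other. Nothing available gives a cause for this shift.

The compounds shown do not separate the methoxy group from its place on the phenyl ring, as the two change together. On these data alone, how an amine or a carboxylic acid on that ring would read also stays open.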